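The source may hold more compounds than are shown below. What is called first, only, known or untested is meant among the compounds shown, and "the series" means these compounds.

For the measured compounds named here, in an ADME assay on cells (Macrophage, Homo sapiens) for cytotoxicity, read by MTT assay, with a stated time of 24 h (a higher number here means that more compound is tolerated, a lower number that less compound is tolerated), compound 1 `CC(O)Cn1c([N+](=O)[O-])cnc1/C=C/c1ccccc1` gives 1500 nM, the highest of the three numbers measured so far. Compound 2 `CC(O)Cn1c([N+](=O)[O-])cnc1/C=C/c1ccc(F)cc1` gives 420 nM and compound 3 `CC(O)Cn1c([N+](=O)[O-])cnc1/C=C/c1ccc(N(C)C)cc1` gives 680 nM, two values within the scatter of each other. Compound 4 `CC(O)Cn1c([N+](=O)[O-])cnc1/C=C/c1ccccc1[N+](=O)[O-]` differs from compound 1 by one change, (nitro in place of hydrogen on an aromatic carbon), with nitro in place of hydrogen on an aromatic carbon, ortho to a large group. Two measured steps also replace hydrogen on an aromatic carbon, a 3.6-fold lower number from compound 1 to compound 2 (0.55 log units; beyond the scatter) and a 2.2-fold lower number from compound 1 to compound 3 (0.34 log units; beyond the scatter). Both are modest and run the same way, though neither introduces nitro. A similarly modest downward step is therefore expected in this assay, a 2.3-fold lower number from compound 1 to compound 4 (0.36 log units; beyond the scatter). For compound 4 the estimated value is 650 nM, with an expected range from 250 nM to 1700 nM.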

Compound 4, half-maximal cytotoxic concentration: 1090 nM
Estimate against measurement, compound 4: 1.7-fold (0.22 log units) below; measured number inside the range.
By their numbers in this assay, from the lowest: compounds 2, 3, 4 and 1 (each within the scatter of the next, the first and the last beyond it).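

In this assay, nitro on an aromatic carbon, ortho to a large group, gives a 1.4-fold lower number from compound 1 to compound 4 (0.14 log units; within the scatter) and so is the only one of the three replacements of hydrogen whose step stays within the scatter. Because group and place may both differ from those in compound 2 and compound 3, the compounds shown do not separate the two. No available evidence explains the result.

As far as these compounds go, it remains open how nitro would behave elsewhere on this aromatic ring. From the compounds shown here alone, it also remains open how fluoro, methoxy or a carboxylic acid would behave at this position.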